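Replacing the anilide group on a pyrazole carboxamide core

This account rests on a few compounds, and the source may have more. Where it says the series, first, only, none or still open, it means among the compounds named here.

Compound 2 `Cc1ccc(NC(=O)c2c(-c3ccccc3)c(-c3ccccc3)nn2-c2ccccc2)cc1` is the starting point. For the measured compounds named here, in a functional assay on HEp-2 cells (Homo sapiens) for cytotoxicity, with a stated time of 24 h (a higher number here means a weaker inhibitor, a lower number a stronger inhibitor), compound 2 gives 1.21 ug/mL, which places it second highest of the three numbers measured so far. Its nearest neighbour is compound 1 `O=C(Nc1ccccc1)c1c(-c2ccccc2)c(-c2ccccc2)nn1-c1ccccc1`, which in this assay gives 1.5 ug/mL; the step of a 1.2-fold lower number from compound 1 to compound 2 (0.09 log units; within the scatter) stays within the scatter. Compound 3 `Cc1ccc(NC(=O)c2c(-c3ccc(Cl)cc3)c(-c3ccccc3)nn2-c2ccccc2)cc1` gives 0.81 ug/mL in this assay, and the step of a 1.5-fold lower number from compound 2 to compound 3 (0.17 log units; within the scatter) likewise stays within the scatter.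

Compound 4 `O=C(c1c(-c2ccccc2)c(-c2ccccc2)nn1-c1ccccc1)n1c(=S)[nH]c2ccccc21` differs from compound 2 in a single place: a group of 10 heavy atoms (7 carbon, 2 nitrogen, 1 sulfur; one five-membered aromatic ring with 2 hetero atoms, one six-membered aromatic ring of carbon only) in place of a group of 8 heavy atoms (7 carbon, 1 nitrogen; one six-membered aromatic ring of carbon only), on a carbonyl carbon. Both measured steps concern a hydrogen swapped for a small group on an aromatic ring while the amide itself stayed intact, and neither moved the number beyond the scatter. The change to compound 4 is of a different kind, since it removes the whole (4-methylphenyl)amino group attached to the carbonyl carbon, so the measured steps give little guidance. Going by the values given here, with no closely related step to lean on, compound 4 is expected to stay near compound 2, and the step of a 1.1-fold higher number from compound 2 to compound 4 (0.03 log units; within the scatter) is estimated to lie within the scatter, with wide uncertainty. Compound 4 is therefore estimated at 1.3 ug/mL in this assay, in a range from 0.4 ug/mL to 4.5 ug/mL.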

Compound 4, half-maximal inhibitory concentration: 7.18 ug/mL
The estimate for compound 4 lay 5.5-fold (0.74 log units) below the measured number; measured number above the stated range.
By their numbers in this assay, from the lowest: compounds 3, 2 and 1 (each within the scatter of the next); then compound 4.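

In this assay, for the compounds shown here, the group on the carbonyl carbon is the first place where a single change moves the number beyond the scatter. Putting the sulfur-bearing two-ring group in place of the (4-methylphenyl)amino group gives a 5.9-fold higher number from compound 2 to compound 4 (0.77 log units; beyond the scatter), which means a weaker inhibitor, and the same swap on the version without the methyl gives a 4.8-fold higher number from compound 1 to compound 4 (0.68 log units; beyond the scatter), so the two steps agree in direction. No measurement in hand accounts for this rise.

From the compounds shown here alone, whether the rise belongs to this particular group, or would follow any replacement of the (4-methylphenyl)amino group, stays open. A morpholine or a methoxy group on the carbonyl carbon would help to tell these two readings apart.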